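The source may report more compounds than this note shows. Statements on the series, on what has been measured and on what is new or still open speak of the compounds shown alone.

Measured so far in an ADME assay on RAW264.7 cells (Mus musculus) for cytotoxicity, read by MTT assay, with a stated time of 24 h; a higher number here means a weaker inhibitor, a lower number a stronger inhibitor: compound 1 `O=C(O)CN1C(=O)/C(=C/c2ccc(OCC(=O)Nc3cccc(Cl)c3)cc2)SC1=S` gives > 80000 nM. In this assay compound 2 `COCN1C(=O)S/C(=C\c2ccc(OCC(=O)Nc3cccc(Cl)c3)cc2)C1=O` gives 72500 nM.

The value of compound 1, > 80000 nM, is a limit of the assay, not a number (the limit of > 80000 nM in this assay, at which 1 of the 2 values shown sits). Compound 2, with 72500 nM, holds the only number shown in this assay and sits near the upper end of the range the assay reports. The next compound, compound 3 `CC(CN(C)C)CN1C(=O)S/C(=C\c2ccc(OCC(=O)Nc3cccc(Cl)c3)cc2)C1=O`, differs from compound 2 by one change: 1-((dimethylamino)methyl)ethyl in place of methoxy on a saturated chain carbon bound to an amide-type nitrogen in a ring. Among the measured compounds shown here, no measured pair shows this change; its effect in this assay is unknown. Given that compound 2 gives 72500 nM, he expects for compound 3 only a small step, not clearly beyond the scatter, in either direction. His estimate for compound 3 is 55000 nM, within 15000 nM to 90000 nM, which corresponds to an expected step of a 1.3-fold lower number from compound 2 to compound 3 (0.12 log units; within the scatter).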

Compound 3, half-maximal inhibitory concentration: > 80000 nM
Compound 3 gave a limit, no number; the forecaster's own chance of this, stated with the estimate: 40%; middle value at least 1.4-fold (0.16 log units) away from the limit.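

Among the compounds shown here, this is the first measured pair at this place on the saturated chain carbon bound to an amide-type nitrogen in a ring, and in this assay the change gives an at least 1.1-fold higher number from compound 2 to compound 3 (0.04 log units; that floor lies within the scatter). So the much larger 1-((dimethylamino)methyl)ethyl, with 6 heavy atoms in place of the 2 of methoxy, did not bring the read-out to a lower number than that of compound 2. Compound 3 gives a limit of the assay and not a number, and it joins the compounds at that limit: the limit of > 80000 nM in this assay, at which 2 of the 3 values shown sit.

On these data alone, how far the true value of compound 3 lies past the limit stays open, and with it the full size of this step. Also open, as far as these compounds go, is whether a primary amine or a hydroxyl group at the same place would bring the number down.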